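The compounds below may be only part of what the source reports. "The series", "measured", "known", "first", "only" and "open" are said of these compounds alone.

Measured so far, in a functional assay on A549 cells (Homo sapiens) for cytotoxicity, read by sulforhodamine B assay; a lower number here means a stronger inhibitor, a higher number a weaker inhibitor:

compound 1 `COc1cc(C[C@@H]2CO[C@@H](c3ccc(O)c(OC)c3)[C@@H]2CO[C@@H]2O[C@@H](C)[C@H](O)[C@@H](O)[C@H]2O)ccc1O` — only a limit in this assay: compound 1 gives > 10000 nM
compound 2 `COc1cc([C@H]2Oc3c(OC)cc(CCCO)cc3[C@@H]2CO[C@@H]2O[C@@H](C)[C@H](O)[C@@H](O)[C@H]2O)cc(OC)c1O` — only a limit in this assay: compound 2 gives > 10000 nM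
compound 3 `COc1cc([C@H]2Oc3c(OC)cc(CCCO)cc3[C@@H]2CO[C@@H]2O[C@H](CO)[C@@H](O)[C@H](O)[C@H]2O)ccc1O` — only a limit in this assay: compound 3 gives > 10000 nM

Compound 3 stands nowhere in particular on these numbers: its value is a limit, not a measured number, and the same holds for the two other compounds, so no order among the three can be read. Going by the values given here, the shared situation is the limit of > 10000 nM in this assay, at which 3 of the 3 values shown sit; no step between measured compounds exists that could be sized.

The unmeasured compound 4 `COc1cc([C@H]2Oc3c(OC)cc(CCCO)cc3[C@@H]2CO[C@@H]2O[C@@H](C)[C@H](O)[C@@H](O)[C@H]2O)ccc1O` differs from compound 3 in the sugar only: 3,4,5-trihydroxy-6-methyloxan-2-yl in place of 3,4,5-trihydroxy-6-(hydroxymethyl)oxan-2-yl on an oxygen on a saturated carbon. Compound 2 carries the same 3,4,5-trihydroxy-6-methyloxan-2-yl sugar and also sits at the limit, and compound 3 with the 3,4,5-trihydroxy-6-(hydroxymethyl)oxan-2-yl sugar sits there too, so nothing in the data points to a change on swapping one for the other.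

Expectation for the step from compound 3 to compound 4 in this assay: a step that the limit leaves unreadable from compound 3 to compound 4, that is, none beyond the scatter, with the result most probably again a limit. The estimated value for compound 4 is 15000 nM, with the range expected between 8000 nM and 40000 nM.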

Compound 4, half-maximal inhibitory concentration: > 10000 nM
Compound 4: no number, only a limit; the forecaster's own chance of this, stated with the estimate: 85%; the middle value is on the limit's open side.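

Compound 4 gives > 10000 nM, a limit and not a number. Going by these compounds alone, neither the step from compound 3 to compound 4 nor the one from compound 2 to compound 4 can be read. The compounds shown leave open whether either change alters the result in this assay, and how any of them ranks against the others.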